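The compounds below may be only part of what the source reports. "The series", "measured", "known", "first", "only" and "open" are said of these compounds alone.

Compound 1 `CCC(C)n1ncn(-c2ccc(N3CCN(c4ccc(OC[C@@H]5CO[C@@](Cn6cncn6)(c6ccc(Cl)cc6Cl)O5)cn4)CC3)c(F)c2)c1=O` and compound 2 `CCC(C)n1ncn(-c2ccc(N3CCN(c4ccc(OC[C@@H]5CO[C@@](Cn6ccnc6)(c6ccc(Cl)cc6Cl)O5)cn4)CC3)c(F)c2)c1=O` share one core, while compound 3 `CCC(C)n1ncn(-c2ccc(N3CCN(c4ccc(OC[C@@H]5CO[C@@](Cn6cncn6)(c6ccc(Cl)cc6Cl)O5)cc4)CC3)nc2)c1=O` and compound 4 `CCC(C)n1ncn(-c2ccc(N3CCN(c4ccc(OC[C@@H]5CO[C@@](Cn6ccnc6)(c6ccc(Cl)cc6Cl)O5)cc4)CC3)nc2)c1=O` share another; how the two cores differ is not broken down here. In a physicochemical assay for solubility, read by HPLC, measured as thermodynamic solubility (on this read-out higher numbers stand for higher solubility and lower numbers for lower solubility), compound 1 gives 0.848 ug/mL and compound 2 gives 125 ug/mL. Within the data shown here, the only change between these two is 1H-imidazol-1-yl in place of 1H-1,2,4-triazol-1-yl on a saturated chain carbon bound to a saturated ring carbon, and that change made a 150-fold higher number from compound 1 to compound 2 (2.17 log units; beyond the scatter). In this assay compound 3 gives 0.0539 ug/mL, the lowest of the three measured numbers, and its steps to compound 1 and to compound 2 both lie beyond the scatter. Compound 4 has not yet been measured. Among the measured compounds shown here, it differs from compound 3 by 1H-imidazol-1-yl in place of 1H-1,2,4-triazol-1-yl on a saturated chain carbon bound to a saturated ring carbon, which is the same change, at the same place, as the one that separates compound 1 from compound 2. The expectation for compound 4 therefore rests on one measured pair alone. The step from compound 3 to compound 4 in this assay is expected to be a 93-fold higher number from compound 3 to compound 4 (1.97 log units; beyond the scatter), set somewhat below the earlier step because a 150-fold higher number from compound 1 to compound 2 (2.17 log units; beyond the scatter) comes from a single pair on a different core and a step that large may not carry over in full. On that basis compound 4 is estimated to give 5 ug/mL, with an expected range from 0.5 ug/mL to 40 ug/mL.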

Compound 4, solubility: 7.99 ug/mL
Beside the measured number, compound 4's estimate is 1.6-fold (0.20 log units) below it; low and high end bracket the measured number.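

In this assay, placing 1H-imidazol-1-yl where 1H-1,2,4-triazol-1-yl stood, on a saturated chain carbon bound to a saturated ring carbon, gave a 150-fold higher number from compound 3 to compound 4 (2.17 log units; beyond the scatter) on one core and a 150-fold higher number from compound 1 to compound 2 (2.17 log units; beyond the scatter) on the other, so the step has the same printed size on both cores. This shows that, for these two pairs, the change carried over in full from one core to the other, but two pairs cannot show that it would carry over in the same way to every core in this series. No information is available on why the step has this size or why it repeats here.

The compounds shown have only these two groups at this place, so it remains open how another group there, such as a primary amine, a carboxylic acid or a longer chain ending in either of the two rings, would read in this assay and whether the step would keep its size on a third core. They also leave open whether this change would matter in the same way for any property other than the one read here.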